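Trifluoromethyl for Chloro in a Dichloroacetamide Series

The source may hold more compounds than are shown below. What is called first, only, known or untested is meant among the compounds shown, and "the series" means these compounds.

Compound 1 `O=C(Nc1cccc(-c2ccc(F)cc2)c1)C(Cl)Cl`: 7840 nM
Compound 2 `Nc1cccc(-c2cccc(NC(=O)C(Cl)Cl)c2)c1`: 50000 nM
Compound 3 `O=C(Nc1cccc(-c2ccc(Cl)cc2)c1)C(Cl)Cl`: 36200 nM

All three were measured in a functional assay on A549 cells (Homo sapiens) for cytotoxicity, read by MTT assay, with a stated time of 68 h; a higher number here means a weaker inhibitor, a lower number a stronger inhibitor. Compound 3 gives the second highest of the three numbers; compound 2 lies close to it, within the scatter, while compound 1 sits well below it. Compound 4 `O=C(Nc1cccc(-c2ccc(C(F)(F)F)cc2)c1)C(Cl)Cl` differs from compound 3 in one place: trifluoromethyl in place of chloro on an aromatic carbon. Going by the values given here, the only measured step that bears on this position is a 4.6-fold higher number from compound 1 to compound 3 (0.66 log units; beyond the scatter), a modest rise. Among the compounds with values here, no step from chloro to trifluoromethyl has been measured, so the direction is uncertain, and a step of similar size either way would not surprise. The step expected in this assay is a 1.2-fold lower number from compound 3 to compound 4 (0.08 log units; within the scatter). Compound 4 is estimated at 30000 nM, with a range from 10000 nM to 80000 nM.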

Compound 4, half-maximal inhibitory concentration: 23500 nM
Estimate against measurement, compound 4: 1.3-fold (0.11 log units) above, and the stated range covers the measured number.
By their numbers in this assay, from the lowest: compound 1; then compounds 4, 3 and 2 (each within the scatter of the next, the first and the last beyond it).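

Trifluoromethyl on this aromatic carbon, para to a large group, gives a number that cannot be told apart from that of chloro (a 1.5-fold lower number from compound 3 to compound 4 (0.19 log units; within the scatter)). Going by these compounds alone, compound 1, with fluoro, remains clearly separate from the trifluoromethyl compound as well (a 3.0-fold higher number from compound 1 to compound 4 (0.48 log units; beyond the scatter)), so within these three compounds the only step beyond the scatter at this position is the one from fluoro to either larger group. Nothing available here explains these differences.

The compounds shown leave open how a methoxy group, a nitrile or a carboxylic acid would read at this position. They also leave open whether the parent with hydrogen there would lie nearer compound 1 or compound 3.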